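Moving the chlorine on the triazole-linked phenyl ring

A few compounds are considered here, and "the series" means these few. Any claim that something is new, unique, unknown or untested is made for them only; others in the source may bear on it.

Compound 1 `O=c1[nH]cc(S(=O)(=O)Nc2ccccc2-c2cn(-c3ccc(F)cc3)nn2)c(=O)[nH]1` is recorded in an ADME assay on L02 cells (Homo sapiens) for cytotoxicity, read by MTT assay, with a stated time of 24 h (a higher number here means that more compound is tolerated, a lower number that less compound is tolerated), as "not toxic" (no number reported). Compound 2 `O=c1[nH]cc(S(=O)(=O)Nc2ccccc2-c2cn(-c3cccc(Cl)c3)nn2)c(=O)[nH]1` reaches only a limit of this assay, > 100000 nM, and no number. Compound 2 thus stands at the limit of > 100000 nM in this assay, at which 1 of the 2 values shown sits, with no single figure to place it. Compound 3 `O=c1[nH]cc(S(=O)(=O)Nc2ccccc2-c2cn(-c3ccc(Cl)cc3)nn2)c(=O)[nH]1` carries 4-chlorophenyl in place of 3-chlorophenyl on an aromatic nitrogen. Without a measured step to lean on, the change is expected to stay within the scatter, a step that the limit leaves unreadable from compound 2 to compound 3. Compound 3 is therefore estimated at 150000 nM, between 50000 nM and 500000 nM, most likely again reported only as a limit.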

Compound 3, half-maximal cytotoxic concentration: 16800 nM
Compound 3: middle estimate off by 8.9-fold (0.95 log units), on the high side; measured number below the stated range.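

In this assay, for the compounds shown here, where the chlorine sits on the phenyl ring on the aromatic nitrogen makes a difference that the earlier compounds could not show: 4-chlorophenyl in place of 3-chlorophenyl gives an at least 5.9-fold lower number from compound 2 to compound 3 (0.77 log units; beyond the scatter) and so the first single number. That step is only a minimum because compound 2 stands at a limit: the limit of > 100000 nM in this assay, at which 1 of the 3 values shown sits.

From the compounds shown here alone, what a carboxylic acid or an amine in place of the chlorine of compound 3 would do in this assay remains open. So does whether a methoxy group there would follow compound 2 or compound 3.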